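The source may report more compounds than this note shows. Statements on the series, on what has been measured and on what is new or still open speak of the compounds shown alone.

Compound 1 (`O=C1c2ccc(OCc3cccc(-c4ccc(Cl)cc4F)c3)cc2CN1C1CCCC1`) offers no starting number: in an ADME assay on microsomes from liver (Rattus norvegicus) for metabolic stability, read by LC-MS, with a stated time of 1 h, at 37 degrees C, tested at 4 uM (a higher number here means that more of the compound is left, a lower number that less of the compound is left), compound 1 stands at "not determined" (no result reported). Two relatives do have values. In this assay compound 2 (`O=C(O)c1cc(-c2cccc(COc3ccc4c(=O)n(CC5CC5)sc4c3)c2)ccc1Cl`) gives 75%, and compound 3 (`CN(C)C(=O)c1cc(-c2cccc(COc3ccc4c(=O)n(C5CCCC5)sc4c3)c2)ccc1Cl`) gives 92%. Both differ from compound 1 in more than one place. Next in line is compound 4 (`COc1ccc(C(=O)O)cc1-c1cccc(COc2ccc3c(c2)CN(C2CCCC2)C3=O)c1`). The change is 5-carboxy-2-methoxyphenyl in place of 4-chloro-2-fluorophenyl on an aromatic carbon, with 5-carboxy-2-methoxyphenyl in place of 4-chloro-2-fluorophenyl on an aromatic carbon, meta to a large group. Going by the values given here, no measured step shows what this swap does, so a step in this assay can only be expected loosely, and none beyond the scatter is assumed in either direction. Among the compounds with values here, the expectation leans on compound 2, the only measured compound with a carboxy group, at 75%. For compound 4 the estimated value is 80%, with an expected range of 60% to 95%.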

Compound 4, percent of the compound remaining: 30%
Estimate against measurement, compound 4: 50 percentage points above; measured number outside the range, below it.
By their numbers in this assay, from the lowest: compound 4; then compound 2; then compound 3.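

Going by these compounds alone, with compound 1 at "not determined" (no result reported) in this assay, no step to compound 4 can be read. The compounds shown leave open what 5-carboxy-2-methoxyphenyl alone does to the percent remaining. No evidence on hand accounts for the result of compound 4.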